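Swapping chloro for bromo on compound 2

The source may hold more compounds than are shown below. What is called first, only, known or untested is meant among the compounds shown, and "the series" means these compounds.

compound 1 `CCOc1ccc(Br)cc1-c1cc(Nc2ccc(B(O)O)cc2)nc(N)n1` gives 500 nM
compound 2 `CCOc1ccc(Cl)cc1-c1cc(Nc2ccc(Cl)cc2)nc(N)n1` gives 70 nM

In a functional assay on DU-145 cells (Homo sapiens) for inhibition (a higher number here means a weaker inhibitor, a lower number a stronger inhibitor), compound 2 has the lower of the two numbers, and compound 1 lies higher, beyond the scatter. Compound 3 `CCOc1ccc(Br)cc1-c1cc(Nc2ccc(Cl)cc2)nc(N)n1` is compound 2 with bromo in place of chloro on an aromatic carbon, para to an ethoxy group bromo in place of chloro on an aromatic carbon and nothing else altered. Among the compounds with values here, no measured pair shows this swap alone, since compound 1 also differs elsewhere. No step beyond the scatter is expected in this assay here, so compound 2 with 70 nM serves as the anchor. The expected step is a 1.1-fold higher number from compound 2 to compound 3 (0.03 log units; within the scatter) and stays within the scatter. For compound 3 the estimated value is 75 nM with an expected range from 30 nM to 180 nM in this measurement.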

Compound 3, half-maximal inhibitory concentration: 80 nM
Estimate against measurement, compound 3: 1.1-fold (0.03 log units) below; measured number inside the range.
By their numbers in this assay, from the lowest: compounds 2 and 3 (each within the scatter of the next); then compound 1.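

In this assay, bromo and chloro on this aromatic carbon, para to an ethoxy group, cannot be told apart, with a step of a 1.1-fold higher number from compound 2 to compound 3 (0.06 log units; within the scatter). With bromo kept in place, a different swap on an aromatic carbon, one chlorine atom for the boronic acid group, gives a clear step of a 6.3-fold lower number from compound 1 to compound 3 (0.80 log units; beyond the scatter). Nothing available explains either result. Still open, from the compounds shown here alone, is how fluoro or iodo would behave at the bromo position, and whether an amine or a carboxylic acid could stand in place of that chlorine.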